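Demethylation of a Methoxy Group in a Pyrazole Urea Series

This account rests on a few compounds, and the source may have more. Where it says the series, first, only, none or still open, it means among the compounds named here.

Measured compounds: compound 1 `COc1cc(-c2nn(-c3cccc(NC(=O)Nc4cc(C(F)(F)F)cc(C(F)(F)F)c4)c3)cc2-c2ccncc2)ccc1Cl` gives 2550 nM; compound 2 `COc1cc(-c2nn(-c3cccc(NC(=O)Nc4ccc(Cl)c(Cl)c4)c3)cc2-c2ccncc2)ccc1Cl` gives 2690 nM; compound 3 `O=C(Nc1cccc(-n2cc(-c3ccncc3)c(-c3ccc(Cl)c(O)c3)n2)c1)Nc1ccc(Cl)c(Cl)c1` gives 6970 nM.

In a functional assay on M14 cells (Homo sapiens) for inhibition, read by sulforhodamine B assay, with a stated time of 48 h (on this read-out lower numbers stand for stronger inhibition of growth and higher numbers for weaker inhibition of growth), compound 1 and compound 2 lie within the scatter of each other; the difference between the two cores is not broken down here. From compound 2 to compound 3 the change is hydrogen in place of methyl on an oxygen on an aromatic ring, and it gave a 2.6-fold higher number from compound 2 to compound 3 (0.41 log units; beyond the scatter). Compound 4 `O=C(Nc1cccc(-n2cc(-c3ccncc3)c(-c3ccc(Cl)c(O)c3)n2)c1)Nc1cc(C(F)(F)F)cc(C(F)(F)F)c1` is not yet measured; it differs from compound 1 by hydrogen in place of methyl on an oxygen on an aromatic ring, the same change made at the same place. Because the step of a 2.6-fold higher number from compound 2 to compound 3 (0.41 log units; beyond the scatter) was modest but beyond the scatter, a step of similar size is expected from compound 1 to compound 4, namely a 2.5-fold higher number from compound 1 to compound 4 (0.41 log units; beyond the scatter). Compound 4 is therefore estimated at 6500 nM, with a range from 3000 nM to 14000 nM.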

Compound 4, concentration for total growth inhibition: 1810 nM
Compound 4: middle estimate off by 3.6-fold (0.56 log units), on the high side; measured number outside the range, below it.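

On the second core, the change from methoxy to hydroxy gave a 1.4-fold lower number from compound 1 to compound 4 (0.15 log units; within the scatter) in this assay, so the rise in the number seen on the first core did not recur. The same change therefore did not carry over from one core to the other with the same size: the same change on two cores in this assay, a 2.6-fold higher number (0.41 log units; beyond the scatter) from compound 2 to compound 3 and a 1.4-fold lower number (0.15 log units; within the scatter) from compound 1 to compound 4, 3.7-fold (0.56 log units) apart, beyond the scatter of two such steps. This shows that a step measured on one core was a poor guide to the other here, but it does not show which difference between the two cores is responsible, or how the change would behave on any further core.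

As far as these compounds go, whether an ethyl group on that oxygen would follow either step remains open. So does the outcome of an amine in place of the hydroxy group on each core.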